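Amino for chloro on the fused ring of compound 2

The source may report more compounds than this note shows. Statements on the series, on what has been measured and on what is new or still open speak of the compounds shown alone.

Measured so far:
- compound 1, `Nc1nn(C(=O)Nc2ccc(Cc3ccccc3)cc2)c2ccccc12`: 17600 nM
- compound 2, `Nc1nn(C(=O)Nc2ccc(Cc3ccccc3)cc2)c2ccc(Cl)cc12`: 24000 nM

Compound 2 holds the highest number of the two in a functional assay on HT-29 cells (Homo sapiens) for antiproliferative activity, read by sulforhodamine B assay, with a stated time of 48 h (a lower number here means a stronger inhibitor of growth, a higher number a weaker inhibitor of growth), with compound 1 its nearest neighbour; the step of a 1.4-fold higher number from compound 1 to compound 2 (0.13 log units; within the scatter) lies within the scatter, so the two compounds cannot be ordered on these data.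

Compound 3, `Nc1ccc2c(c1)c(N)nn2C(=O)Nc1ccc(Cc2ccccc2)cc1`, is not yet measured. It differs from compound 2 by amino in place of chloro on an aromatic carbon.

Among the measured compounds shown here, only one measured step touches this position, the exchange from compound 1 to compound 2, and it stayed within the scatter. For the measured compounds named here, no measured pair shows an amino group at that carbon, so the direction of the change is open. Given that the one known variation at this carbon produced no change beyond the scatter, compound 3 is expected to land close to compound 2 in this assay, with an expected step of a 1.2-fold lower number from compound 2 to compound 3 (0.08 log units; within the scatter).

Estimate for compound 3 in this assay: 20000 nM, expected range 8000 nM to 50000 nM.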

Compound 3, concentration for total growth inhibition: 17200 nM
Beside the measured number, compound 3's estimate is 1.2-fold (0.07 log units) above it; the range from low to high includes it.
By their numbers in this assay, from the lowest: compounds 3, 1 and 2 (each within the scatter of the next).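

In this assay this aromatic carbon now carries hydrogen, chloro or amino across the three compounds, and the readings stay together. The steps of a 1.4-fold lower number from compound 2 to compound 3 (0.14 log units; within the scatter) and a 1.0-fold lower number from compound 1 to compound 3 (0.01 log units; within the scatter) both lie within the scatter, so amino, which brings a hydrogen-bond donor and a hydrogen-bond acceptor that chloro lacks, gives no readable difference from either chloro or hydrogen, and compounds 1, 2 and 3 cannot be ordered. No evidence bearing on this result is available.

The compounds shown cover only single-atom substituents at this carbon, so it remains open whether a larger group, such as a carboxylic acid or an acetamide, would move the number beyond the scatter. They also leave open whether this carbon matters at all when the rest of the molecule is changed.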